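This account rests on a few compounds, and the source may have more. Where it says the series, first, only, none or still open, it means among the compounds named here.

This set of three tested compounds, and a fourth still to be tested, shares one core and was examined in an ADME assay on BJ cells (Homo sapiens) for cytotoxicity, read by CellTiter-Glo and resazurin assay, with a stated time of 72 h; a lower number here means that less compound is needed, a higher number that more compound is needed for the effect. Compound 1 is `CC(=O)Nc1cccc(-c2ccc(C(=O)N(Cc3cccc(OCCCCCC(=O)O)c3)C(C)C)cc2)c1`. Compound 2 is `CCOC(=O)CCCCCOc1cccc(CN(C(=O)c2ccc(-c3cccc(N(C)C)c3)cc2)C(C)C)c1`, and compound 3 is `CCOC(=O)CCCCCOc1cccc(CN(C(=O)c2ccc(-c3cccc4ccccc34)cc2)C(C)C)c1`. In this assay compound 1 gives > 26000 nM, which is a limit of the assay rather than a number. For compound 2 the reading is > 26000 nM, again a limit. Compound 3 likewise gives > 26000 nM, also a limit. Compound 3 thus stands at the limit of this assay, as do the other two, and the three cannot be set in any order. Among the compounds with values here, the only measured step that changes a single place, a step that the two limits leave unreadable from compound 2 to compound 3, has a size that cannot be read because of the limit of > 26000 nM in this assay, at which 3 of the 3 values shown sit. The compound still to be measured, compound 4, is `CCOC(=O)CCCCCOc1cccc(CN(C(=O)c2ccc(-c3cccc(NC(C)=O)c3)cc2)C(C)C)c1`. It differs from compound 3 by 3-acetamidophenyl in place of naphthalen-1-yl on an aromatic carbon. Within the data shown here, no measured step offers a readable size, so the expectation rests on where all three measured values sit, namely at the limit. For compound 4 the expected step is a step that the limit leaves unreadable from compound 3 to compound 4, that is, no change that could be read. Compound 4 is therefore estimated at 40000 nM, with a range from 20000 nM to 100000 nM.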

Compound 4, half-maximal effective concentration: > 26000 nM
Compound 4 was reported as a limit; the forecaster's own chance of this, stated with the estimate: 85%; the middle value is on the limit's open side.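

In this assay compound 4 gives > 26000 nM and this is again a limit. Its steps from compound 1, compound 2 and compound 3 cannot be read, because of where all the values sit: the limit of > 26000 nM in this assay, at which 4 of the 4 values shown sit. Left open is whether any change to these four compounds would shift the result in this assay to a readable number.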